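The source may hold more compounds than are shown below. What is called first, only, known or untested is meant among the compounds shown, and "the series" means these compounds.

In an ADME assay on HepG2 2.2.15 cells (Homo sapiens) for cytotoxicity, read by MTT assay, with stated times of 48 h and 9 days (on this read-out higher numbers stand for lower toxicity in this test and lower numbers for higher toxicity in this test), the three measured compounds gave these numbers:

Compound 1 `COc1ccc(CNC(=O)/C=C/c2coc3cc(O)ccc3c2=O)cc1`: 718000 nM
Compound 2 `O=C(/C=C/c1coc2cc(O)ccc2c1=O)NCc1ccccc1`: 436000 nM
Compound 3 `COc1ccc2c(=O)c(/C=C/C(=O)NCc3ccccc3)coc2c1`: 376000 nM

Compound 3 differs from compound 2 and from compound 1 only within the usual scatter, so the three cannot be told apart on these numbers. Compound 4 `COc1ccc2c(=O)c(/C=C/C(=O)Nc3ccccc3Cl)coc2c1` arises from compound 3 by 2-chlorophenyl in place of benzyl on an amide-type nitrogen. Among the measured compounds shown here, no measured step changes the group on the amide nitrogen. The nearest guides are a 1.6-fold lower number from compound 1 to compound 2 (0.22 log units; within the scatter), a change on the benzyl ring, and a 1.2-fold lower number from compound 2 to compound 3 (0.06 log units; within the scatter), a change on the shared core, both within the scatter. In this assay the change from compound 3 to compound 4 is therefore expected to produce no step beyond the scatter, a 1.1-fold lower number from compound 3 to compound 4 (0.03 log units; within the scatter). Compound 4 is expected to give about 350000 nM, between 150000 nM and 800000 nM.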

Compound 4, half-maximal cytotoxic concentration: 1010000 nM
Estimate against measurement, compound 4: 2.9-fold (0.46 log units) below; measured number outside the range, above it.
By their numbers in this assay, from the lowest: compounds 3, 2, 1 and 4 (each within the scatter of the next, the first and the last beyond it).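

In this assay, among the compounds shown here, the group on the amide-type nitrogen moves the number more than the earlier changes on the benzyl ring and the shared core did: 2-chlorophenyl in place of benzyl gives a 2.7-fold higher number from compound 3 to compound 4 (0.43 log units; beyond the scatter) and is the only single change here that goes beyond the scatter, though modestly. Nothing measured here accounts for this step.
From the compounds shown here alone, it remains open whether the chlorine or the loss of the carbon linking ring and nitrogen carries the step. Plain phenyl on this nitrogen would separate the two, and a phenethyl group would extend the comparison to a longer chain.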